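The source may report more compounds than this note shows. Statements on the series, on what has been measured and on what is new or still open speak of the compounds shown alone.

Measured in a functional assay on DU-145 cells (Homo sapiens) for cytotoxicity; a lower number here means a stronger inhibitor of growth, a higher number a weaker inhibitor of growth:
- compound 1 `CSc1ccc(C2=C(c3ccc(O)c(O)c3)C(=O)N3CCCC3C2)cc1`: 60000 nM
- compound 2 `CSc1ccc(C2=C(c3ccc(Br)cc3)C(=O)N3CCCC3C2)cc1`: 9000 nM

Compound 2, at 9000 nM, holds the lower of the two numbers in this assay, so it is the stronger growth inhibitor of the pair. Compound 3 `CSc1ccc(C2=C(c3ccc(F)cc3)C(=O)N3CCCC3C2)cc1` has yet to be measured. It differs from compound 2 by fluoro in place of bromo on an aromatic carbon, with fluoro in place of bromo on an aromatic carbon, para to a large group. Within the data shown here, only one measured step bears on this: a 6.7-fold lower number from compound 1 to compound 2 (0.82 log units; beyond the scatter), a modest step that introduced the 4-bromophenyl group. Among the measured compounds shown here, that exchange was much larger than the present one, and no measured pair compares bromo with fluoro, so it offers only loose guidance. A smaller shift is therefore expected, at most slightly beyond the scatter and tentatively toward a higher number, with the expected step being a 1.6-fold higher number from compound 2 to compound 3 (0.19 log units; within the scatter). For compound 3 the estimated value is 14000 nM, with an expected range of 6000 nM to 35000 nM.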

Compound 3, concentration for 50% growth inhibition: 500 nM
Compound 3: the middle estimate sits 28-fold (1.45 log units) above what was measured; measured number below the stated range.
By their numbers in this assay, from the lowest: compound 3; then compound 2; then compound 1.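

In this assay, among these compounds, the earlier compounds showed only that replacing the whole 3,4-dihydroxyphenyl group changed growth inhibition, a 6.7-fold lower number from compound 1 to compound 2 (0.82 log units; beyond the scatter). The new result shows that a single halogen atom on this aromatic carbon, para to a large group, also matters a great deal: the exchange of bromo for fluoro gives an 18-fold lower number from compound 2 to compound 3 (1.26 log units; beyond the scatter), and the 4-fluorophenyl group gives a 120-fold lower number from compound 1 to compound 3 (2.08 log units; beyond the scatter), so the three aryl groups span a wide range at this one position. Nothing shown here gives a measured explanation for this difference.

The compounds shown leave open whether chloro or plain hydrogen on this carbon would fall between compound 2 and compound 3 or outside them. On these data alone, it also remains open whether a trifluoromethyl or an amine group there would match compound 3.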